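The compounds below may be only part of what the source reports. "The series", "measured", "known", "first", "only" and "open" are said of these compounds alone.

Working notes on the series.

Compound 1, `Cn1cccc1C(=O)/C=C/c1ccc2c(c1)B(O)OC2`, is the starting point. In a functional assay on HCT-116 cells (Homo sapiens) for cytotoxicity, read by MTT assay, with a stated time of 48 h (a lower number here means a stronger inhibitor, a higher number a weaker inhibitor), compound 1 returns only a limit, > 100000 nM. Compound 2, `O=C(/C=C/c1ccc2c(c1)B(O)OC2)c1ccc(O)c(O)c1`, carries a different aryl group on the carbonyl carbon and otherwise shares the core. In this assay compound 2 likewise returns only a limit, > 100000 nM. Going by the values given here, compound 1 therefore has no numerical position: it stands at the limit of > 100000 nM in this assay, at which 2 of the 2 values shown sit, and the values shown so far give no measured step between any two compounds, so nothing is known about how changes on the carbonyl carbon move the read-out.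

Compound 3, `Nc1cccc(C(=O)/C=C/c2ccc3c(c2)B(O)OC3)c1`, is not yet measured in this assay. It differs from compound 1 by 3-aminophenyl in place of 1-methyl-1H-pyrrol-2-yl on a carbonyl carbon.

With both measured compounds sitting at the limit, no step beyond the scatter is expected from compound 1 to compound 3; the estimated step is a step that the limit leaves unreadable from compound 1 to compound 3, in no preferred direction. Compound 3 is accordingly expected to give about 150000 nM in this assay, within an estimated range of 40000 nM to 600000 nM, and most probably to return a limit rather than a number.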

Compound 3, half-maximal inhibitory concentration: 4500 nM
For compound 3 the middle estimate is 33-fold (1.52 log units) above the measured one, and the stated range ends above it.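

Going by these compounds alone, the carbonyl carbon is a position that can move the read-out: in this assay, 3-aminophenyl in place of 1-methyl-1H-pyrrol-2-yl gives an at least 22-fold lower number from compound 1 to compound 3 (1.34 log units; beyond the scatter), a large step beyond the scatter that the earlier compounds could not show. A phenyl ring at this position does not by itself yield a measurable number, as compound 2, which also carries a substituted phenyl on the carbonyl carbon, returns only a limit, > 100000 nM. Within the data shown here, compound 3 therefore stands alone as the one compound with a number, while the rest of the series remains at a limit: the limit of > 100000 nM in this assay, at which 2 of the 3 values shown sit.

From the compounds shown here alone, the step between compound 1 and compound 2 cannot be read, the full size of the step to compound 3 stays open, and the change from compound 1 to compound 3 alters both the ring and the amine at once, so the share of each in the step is unknown. A plain phenyl on the same carbonyl carbon, or a hydroxyl or an acetamide in place of the amine, would separate the ring from the amine.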